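The source may hold more compounds than are shown below. What is called first, only, known or untested is meant among the compounds shown, and "the series" means these compounds.

Measured so far in a functional assay on MIA PaCa-2 cells (Homo sapiens) for cytotoxicity, read by MTT assay, with a stated time of 72 h; a higher number here means a weaker inhibitor, a lower number a stronger inhibitor:
Compound 1 `O=C1C(Nc2ccc(OC(F)(F)F)cc2)=CC(=O)c2ncncc21`: 1400 nM
Compound 2 `O=C1C(Nc2ccc(-c3ccccc3)cc2)=CC(=O)c2ncncc21`: 900 nM

In this assay, compound 2 gives 900 nM and compound 1 gives 1400 nM. These two values lie within the scatter of each other, so neither compound stands apart. Compound 3 `COc1ccc(NC2=CC(=O)c3ncncc3C2=O)cc1` follows from compound 2 with methoxy in place of phenyl on an aromatic carbon, para to a large group (methoxy in place of phenyl on an aromatic carbon). Among the measured compounds shown here, only one measured step bears on this change: a 1.6-fold lower number from compound 1 to compound 2 (0.19 log units; within the scatter), where phenyl replaces trifluoromethoxy at that same place. For the measured compounds named here, no measurement yet shows methoxy at this place. Going by the values given here, with only that small step as a guide, no change beyond the scatter is expected. The expected step is a 1.3-fold higher number from compound 2 to compound 3 (0.12 log units; within the scatter). For compound 3 the estimated value is 1200 nM, with an expected range from 500 nM to 3000 nM.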

Compound 3, half-maximal inhibitory concentration: 1900 nM
The estimate for compound 3 lay 1.6-fold (0.20 log units) below the measured number; the measured number falls inside the stated range.
By their numbers in this assay, from the lowest: compounds 2, 1 and 3 (each within the scatter of the next, the first and the last beyond it).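

In this assay, among the compounds shown here, methoxy in place of phenyl on an aromatic carbon gives a 2.1-fold higher number from compound 2 to compound 3 (0.32 log units; beyond the scatter) and so provides the first step at this place to lie beyond the scatter, though only modestly. Methyl in place of trifluoromethyl on the oxygen gives a 1.4-fold higher number from compound 1 to compound 3 (0.13 log units; within the scatter) and leaves the two oxygen-linked groups unseparated, so among the three groups shown, only phenyl and methoxy stand apart at this place. Nothing available accounts for that modest difference.

Going by these compounds, it remains open whether an amine, a carboxylic acid or a longer alkoxy chain at this place would shift the number further or leave it within the same narrow band. The compounds shown also leave open whether a second ring joined to the phenyl through an oxygen would behave like phenyl or like methoxy.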